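The compounds below may be only part of what the source reports. "The series", "measured", "known", "first", "only" and "open" are said of these compounds alone.

Three compounds share one core and were tested in an assay on HEK293 cells for inhibition of Voltage-dependent T-type calcium channel subunit alpha-1G (Homo sapiens), read by patch clamp; on this read-out lower numbers stand for stronger inhibition and higher numbers for weaker inhibition. Compound 1 `CCCc1nc(-c2ccccc2)c(CNCCN2CCN(c3ccccc3Cl)CC2)o1` gives 4370 nM. Compound 3 `CCCc1nc(-c2ccccc2)c(CNCCN2CCN(c3ccccc3C(F)(F)F)CC2)o1` gives 2100 nM. Compound 2 `CCCc1nc(-c2ccccc2)c(CNCCCN2CCN(c3ccccc3Cl)CC2)o1` gives 2800 nM. On these three numbers compound 2 sits between the other two: its gap to compound 3 lies within the usual scatter, and so does its gap to compound 1, so none of the three can be separated from compound 2 with confidence.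

Within the data shown here, the one step that reaches beyond the scatter here is a 2.1-fold lower number from compound 1 to compound 3 (0.32 log units; beyond the scatter), a change of the substituent on the aromatic ring that hangs from the ring nitrogen.

Compound 4 `CCCc1nc(-c2ccccc2)c(CNCCCN2CCN(c3ccc(Cl)cc3)CC2)o1` has the same atoms as compound 2, joined differently: 4-chlorophenyl in place of 2-chlorophenyl on an amine nitrogen in a ring. The chlorine is kept, only its place on the aromatic ring changes. Among the measured compounds shown here, no measured pair in this set makes such a move; the step from compound 1 to compound 3 swaps one group for another and does not speak to where a chloro sits. Without a guide, the expectation is that compound 4 lands close to compound 2 in this assay, with the estimated step of no change at the digits printed from compound 2 to compound 4 (within the scatter) counted as none beyond the scatter. Compound 4 is therefore estimated at 2800 nM, within a range from 900 nM to 9000 nM.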

Compound 4, half-maximal inhibitory concentration: 1310 nM
Compound 4: middle estimate off by 2.1-fold (0.33 log units), on the high side; measured number inside the range.
By their numbers in this assay, from the lowest: compounds 4, 3, 2 and 1 (each within the scatter of the next, the first and the last beyond it).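

In this assay the place of the chlorine on the aromatic ring matters on its own: 4-chlorophenyl in place of 2-chlorophenyl on the amine nitrogen in the ring gives a 2.1-fold lower number from compound 2 to compound 4 (0.33 log units; beyond the scatter) with no atom gained or lost. Among these compounds, the earlier result of a 2.1-fold lower number from compound 1 to compound 3 (0.32 log units; beyond the scatter) came from swapping one group for another, whereas here the group stays the same and only its place changes, so the position itself can be read for the first time in this set. Nothing available here accounts for why this move lowers the number.

On these data alone, whether 4-chlorophenyl gives a similar step on the shorter chain of compound 1 remains open, as does whether trifluoromethyl responds to the same move as the chlorine does. Also open, as far as these compounds go, is what a fluoro or a methoxy group would give in place of the chlorine at this same spot, and so whether the step belongs to chlorine alone or to other groups placed there too.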